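Shortening an alkenyl ether chain: what the next compound may show

The source may hold more compounds than are shown below. What is called first, only, known or untested is meant among the compounds shown, and "the series" means these compounds.

Measured so far in a functional assay on LoVo cells (Homo sapiens) for inhibition, read by colorimetric assay and MTT assay, with a stated time of 72 h; on this read-out lower numbers stand for stronger inhibition and higher numbers for weaker inhibition:
Compound 1, `C=CCCCCOc1cc2ccccc2cc1-c1cnc(OCCC=C)n1C`, gives 25000 nM.
Compound 2, `C=CCCCCOc1cc2ccccc2cc1-c1cnc(OCCCCC=C)n1C`, gives 25000 nM.
Compound 3, `C=CCCCCOc1ccccc1-c1cnc(S(=O)(=O)c2ccccc2)n1C`, gives 27000 nM.

Compounds 1 and 2 share one core and differ only in the length of one chain: from compound 2 to compound 1 the change is vinyl in place of but-3-en-1-yl on a saturated chain carbon, two bonds along the chain from an oxygen on an aromatic ring, and the step was no change at the digits printed from compound 2 to compound 1 (within the scatter). Compound 3 has a different core; the difference between the two cores is not broken down here. Its number in this assay lies within the scatter of both compound 1 and compound 2, so none of the three can be called stronger or weaker than another.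

Compound 4, `C=CCCOc1ccccc1-c1cnc(S(=O)(=O)c2ccccc2)n1C`, has not yet been measured. It differs from compound 3 by vinyl in place of but-3-en-1-yl on a saturated chain carbon, two bonds along the chain from an oxygen on an aromatic ring, the same change that was made from compound 2 to compound 1. Because that earlier step was no change at the digits printed from compound 2 to compound 1 (within the scatter), the step from compound 3 to compound 4 is expected to be no change at the digits printed from compound 3 to compound 4 (within the scatter). Compound 4 is therefore estimated at 27000 nM, with a range of 12000 nM to 60000 nM.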

Compound 4, half-maximal inhibitory concentration: 32000 nM
The estimate for compound 4 lay 1.2-fold (0.07 log units) below the measured number, and the stated range covers the measured number.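

In this assay, shortening the chain on the core of compound 3 gives a 1.2-fold higher number from compound 3 to compound 4 (0.07 log units; within the scatter). Set beside the earlier step, the same change behaves alike on both cores: the same change on two cores in this assay, no change at the digits printed (within the scatter) from compound 2 to compound 1 and a 1.2-fold higher number (0.07 log units; within the scatter) from compound 3 to compound 4, 1.2-fold (0.07 log units) apart, within the scatter of two such steps. This shows only that replacing but-3-en-1-yl with vinyl at this place produces no step beyond the scatter on these two cores; it does not show that the change would stay as silent on a third core, nor that the chain could be altered freely in other ways.

The compounds shown leave open what would happen if the chain were replaced by a longer chain, by a saturated chain, or by one carrying an amine or a carboxylic acid. They also leave open whether any such replacement would move the number in this assay beyond the scatter, and whether the two cores would then still respond alike.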